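Swapping a Butyl Chain for a Hydroxyethyl on a Triazole

A few compounds are considered here, and "the series" means these few. Any claim that something is new, unique, unknown or untested is made for them only; others in the source may bear on it.

The measured compounds and their values in a functional assay on SW-620 cells (Homo sapiens) for antiproliferative activity, read by MTT assay, with a stated time of 72 h (a higher number here means a weaker inhibitor, a lower number a stronger inhibitor), are:

Compound 1, `CCCCc1cn(C[C@H](O)[C@H]2OC(=O)C(OCc3ccccc3)=C2OCc2ccccc2)nn1`, gives 47500 nM.
Compound 3, `O=C1O/C(=C\Cn2cc(-c3cccc(O)c3)nn2)C(OCc2ccccc2)=C1OCc1ccccc1`, gives 69800 nM.
Compound 2, `CC(C)(C)OC(=O)N1CCN(C(=S)SCc2cn(C[C@H](O)[C@H]3OC(=O)C(OCc4ccccc4)=C3OCc3ccccc3)nn2)CC1`, reaches only the limit of the assay, > 100000 nM.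

Among the two numbers that were obtained, compound 1 has the lowest, but compound 3 sits so close to it that the two cannot be told apart. For compound 2 only a limit is known, not a number (the limit of > 100000 nM in this assay, at which 1 of the 3 values shown sits).

Compound 4, `O=C1O[C@H]([C@@H](O)Cn2cc(CCO)nn2)C(OCc2ccccc2)=C1OCc1ccccc1`, is the compound yet to be measured. It differs from compound 1 in one place: hydroxy in place of ethyl on a saturated chain carbon, two bonds along the chain from an aromatic carbon. Among the compounds with values here, no step between two measured compounds is known here that would show what such a change does. With nothing to lean on, the step from compound 1 to compound 4 is expected to stay within the usual scatter or lean toward a somewhat higher number, that is, a 1.4-fold higher number from compound 1 to compound 4 (0.14 log units; within the scatter). Compound 4 is therefore estimated at 65000 nM, within a range from 20000 nM to 200000 nM.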

Compound 4, half-maximal inhibitory concentration: > 100000 nM
Compound 4: no number, only a limit; the forecaster's own chance of this, stated with the estimate: 30%; at least 1.5-fold (0.18 log units) between middle value and limit.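

In this assay, the change from butyl to 2-hydroxyethyl on the triazole gives an at least 2.1-fold higher number from compound 1 to compound 4 (0.32 log units; beyond the scatter). So at this position the change weakens the compound by more than the scatter, which none of the earlier compounds could show, although the true size of the step stays unknown. Compound 4 gives no number, only a limit, and it shares that limit with one other compound: the limit of > 100000 nM in this assay, at which 2 of the 4 values shown sit.

The compounds shown leave open whether the weakening comes from losing the ethyl or from gaining the hydroxy, as this one change does both. A plain ethyl chain on the triazole, or an amine or a carboxylic acid in place of the hydroxy, could tell these apart.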